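Trifluoromethoxy to Methyl: Little Change Expected in Cell Inhibition

This account rests on a few compounds, and the source may have more. Where it says the series, first, only, none or still open, it means among the compounds named here.

Compound 1 `CC(c1ccc(-c2ccccc2)c(F)c1)c1nnc2n1N=C(c1ccc(OC(F)(F)F)cc1)CS2`: 4800 nM
Compound 2 `COc1ccc2cc(C(C)c3nnc4n3N=C(c3ccc(Cl)cc3Cl)CS4)ccc2c1`: 14600 nM
Compound 3 `COc1ccc2cc(C(C)c3nnc4n3N=C(c3ccc(C)cc3)CS4)ccc2c1`: 11000 nM

In a functional assay on MCF7 cells (Homo sapiens) for inhibition, read by sulforhodamine B assay, with a stated time of 72 h (on this read-out lower numbers stand for stronger inhibition and higher numbers for weaker inhibition), compound 1 gives the lowest of the three numbers, that is the strongest inhibition, with compound 3 and compound 2 higher by steps beyond the scatter. Compound 4 `Cc1ccc(C2=Nn3c(nnc3C(C)c3ccc(-c4ccccc4)c(F)c3)SC2)cc1` differs from compound 1 in one place: methyl in place of trifluoromethoxy on an aromatic carbon. One measured step alters the same ring: a 1.3-fold lower number from compound 2 to compound 3 (0.12 log units; within the scatter). That step, together with compound 3 already carrying the 4-methylphenyl that enters here, suggests that changing this ring shifts the number little. For compound 4 the expected step is a 1.3-fold higher number from compound 1 to compound 4 (0.10 log units; within the scatter), within the scatter. The estimate for compound 4 is 6000 nM, with a range from 2500 nM to 14000 nM.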

Compound 4, half-maximal inhibitory concentration: 5000 nM
Estimate against measurement, compound 4: 1.2-fold (0.08 log units) above, and the stated range covers the measured number.
By their numbers in this assay, from the lowest: compounds 1 and 4 (each within the scatter of the next); then compounds 3 and 2 (each within the scatter of the next).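

In this assay, putting methyl in place of trifluoromethoxy gives a 1.0-fold higher number from compound 1 to compound 4 (0.02 log units; within the scatter), even though a group of 5 heavy atoms gives way to one of 1 heavy atom. The earlier ring change, between compound 2 and compound 3, involved other groups on this ring and a different group elsewhere in the molecule, so this pair adds a direct test of this position with the rest of compound 1 kept intact.

Going by these compounds, whether an amine or a carboxylic acid here would also leave the number unmoved stays open. Nothing measured here explains why the two numbers match.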